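Moving the Chlorine on the Amide Aryl Ring

A few compounds are considered here, and "the series" means these few. Any claim that something is new, unique, unknown or untested is made for them only; others in the source may bear on it.

Measured so far:
compound 1 `CN1CC[C@@H](c2ccc(Cl)cc2)[C@H](C(=O)NCc2ccc(CNC(=O)c3cccc(C(F)(F)F)c3)cc2)C1` gives > 5000 nM
compound 2 `CN1CC[C@@H](c2ccc(Cl)cc2)[C@H](C(=O)NCc2ccc(CNC(=O)c3ccc(Cl)cc3)cc2)C1` gives 3710 nM

For the measured compounds named here, in an assay on a subcellular fraction from brain for inhibition of sodium-dependent dopamine transporter (Rattus norvegicus) (on this read-out lower numbers stand for stronger inhibition and higher numbers for weaker inhibition), compound 2 gives 3710 nM, the only plain number among the two values shown. Compound 1 reaches only a limit in this assay, > 5000 nM; this is the limit of > 5000 nM in this assay, at which 1 of the 2 values shown sits. Going by the values given here, the sole measured step, an at least 1.3-fold lower number from compound 1 to compound 2 (0.12 log units; that floor lies within the scatter), swaps 3-(trifluoromethyl)phenyl for 4-chlorophenyl. Compound 3 `CN1CC[C@@H](c2ccc(Cl)cc2)[C@H](C(=O)NCc2ccc(CNC(=O)c3cccc(Cl)c3)cc2)C1` differs from compound 2 by 3-chlorophenyl in place of 4-chlorophenyl on a carbonyl carbon. Among the compounds with values here, no measured step shows this exact change; the one step known is small, so a small shift toward weaker inhibition, or none beyond the scatter, is expected. Compound 3 is expected to give 5000 nM, between 2000 nM and 15000 nM, an expected step of a 1.3-fold higher number from compound 2 to compound 3 (0.13 log units; within the scatter).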

Compound 3, inhibition constant: > 4000 nM
Compound 3: only a limit was reported; the forecaster's own chance of this, stated with the estimate: 45%; the middle value lies beyond the limit too.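

Compound 3 reaches only a limit in this assay, not a plain number: the limit of > 4000 nM in this assay, at which 1 of the 3 values shown sits. On these data alone, putting 3-chlorophenyl in place of 4-chlorophenyl on the carbonyl carbon gives an at least 1.0-fold higher number from compound 2 to compound 3 (0.03 log units; that floor lies within the scatter), so moving the chlorine brings no clearly lower number, while the true size of the step stays unknown. The step from compound 1 to compound 3 cannot be read, as both values are limits.

As far as these compounds go, how far the true value of compound 3 lies past its limit stays open. So does whether a methoxy or an amine in place of the chloro would give a lower number.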